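Compound 3: a boron-bearing analogue of compound 2

A few compounds are considered here, and "the series" means these few. Any claim that something is new, unique, unknown or untested is made for them only; others in the source may bear on it.

In a functional assay on B16 cells (Mus musculus) for inhibition (on this read-out lower numbers stand for stronger inhibition and higher numbers for weaker inhibition), compound 1 (`CC(C)CN(CC(=O)N(CC(C)C)NC(=O)OCc1ccccc1)NC(=O)CBr`) gives 3300 nM and compound 2 (`CC(C)CN(NC(=O)OCc1ccccc1)C(=O)CN(Cc1ccccc1)NC(=O)Cc1cccc(Br)c1`) gives 15800 nM. Compound 2 thus stands at the higher of the two numbers, with a gap beyond the usual scatter. Compound 3 (`CC(C)CN(NC(=O)OCc1ccccc1)C(=O)CN(Cc1ccccc1)/N=C/c1cccc(B(O)O)c1`) is not yet measured. The change from compound 2 to compound 3 is a group of 11 heavy atoms (7 carbon, 1 boron, 1 nitrogen, 2 oxygen; one six-membered aromatic ring of carbon only) in place of a group of 11 heavy atoms (8 carbon, 1 nitrogen, 1 oxygen, 1 bromine; one six-membered aromatic ring of carbon only), on an amine nitrogen. For the measured compounds named here, no measured step covers this change, so any expectation is loose. A modest step towards stronger inhibition is expected: a 2.0-fold lower number from compound 2 to compound 3 (0.30 log units; within the scatter). For compound 3 the estimated value is 8000 nM, with an expected range of 1500 nM to 40000 nM.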

Compound 3, half-maximal inhibitory concentration: 18400 nM
Compound 3: the middle estimate sits 2.3-fold (0.36 log units) below what was measured; low and high end bracket the measured number.
By their numbers in this assay, from the lowest: compound 1; then compounds 2 and 3 (each within the scatter of the next).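

In this assay the exchange on the amine nitrogen gives a 1.2-fold higher number from compound 2 to compound 3 (0.07 log units; within the scatter), so this position tolerates the boron-bearing group in place of the bromine-bearing one with no read-out difference. The entering group has 2 hydrogen-bond donors and 3 hydrogen-bond acceptors against 1 of each in the group leaving, and this count difference leaves the number unmoved. No supporting data bear on this result. Open, from the compounds shown here alone, is how a group ending in a carboxylic acid or an amine would read at this nitrogen. Also open, going by these compounds, is whether any part of the exchanged group matters alone, as the group changed as a whole.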